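A few compounds are considered here, and "the series" means these few. Any claim that something is new, unique, unknown or untested is made for them only; others in the source may bear on it.

Measured so far:
compound 1 `O=c1ccoc(/C=C/c2ccccc2)c1`: 509 uM
compound 2 `COc1ccc(/C=C/c2cc(=O)cco2)cc1`: 606 uM
compound 3 `COc1cc(/C=C/C2CC=CC(=O)O2)cc(OC)c1`: 9 uM

All three values come from a functional assay on NCI-H460 cells (Homo sapiens) for inhibition, read by sulforhodamine B assay, with a stated time of 48 h; on this read-out lower numbers stand for stronger inhibition of growth and higher numbers for weaker inhibition of growth. Compound 1 and compound 2 share one core; the change between them is methoxy in place of hydrogen on an aromatic carbon and it gave a 1.2-fold higher number from compound 1 to compound 2 (0.08 log units; within the scatter). Compound 3 carries another core; the difference between the two cores is not broken down here. Its value stands far from the other two, compound 1 being the nearer and compound 2 the further, both gaps beyond the scatter.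

Compound 4 `COc1cc(/C=C/C2CC=CC(=O)O2)cc(OC)c1OC` is not yet measured. It arises from compound 3 by methoxy in place of hydrogen on an aromatic carbon. Among the measured compounds shown here, this is the same kind of change as the one from compound 1 to compound 2, but the surroundings differ: in compound 4 the entering methoxy is ortho to two methoxy groups (2 heavy atoms each) as well as para to a group of 9 heavy atoms, whereas in compound 2 it is only para to a group of 9 heavy atoms. Resting on a 1.2-fold higher number from compound 1 to compound 2 (0.08 log units; within the scatter) and on compound 3 at 9 uM, the expected step is no change at the digits printed from compound 3 to compound 4 (within the scatter), small again. Compound 4 is therefore estimated at 9 uM in this assay, with an expected range from 3 uM to 30 uM.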

Compound 4, concentration for growth inhibition (reported as GI): 28.8 uM
Estimate against measurement, compound 4: 3.2-fold (0.51 log units) below; measured number inside the range.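

In this assay, methoxy in place of hydrogen on an aromatic carbon gives a 3.2-fold higher number from compound 3 to compound 4 (0.51 log units; beyond the scatter), and this step does not match the earlier one on the other core: the same change on two cores in this assay, a 1.2-fold higher number (0.08 log units; within the scatter) from compound 1 to compound 2 and a 3.2-fold higher number (0.51 log units; beyond the scatter) from compound 3 to compound 4, 2.7-fold (0.43 log units) apart, beyond the scatter of two such steps

The size of this change therefore does not carry over intact between the core of compound 1 and the core of compound 3, so a step read on one core is a weak guide to the other. It does not show what sets the difference, since the two pairs differ both in core and in surroundings: the entering methoxy is ortho to two methoxy groups in compound 4, but not in compound 2.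

The compounds shown leave open whether the same methoxy would give a similar step on the core of compound 3 without those two methoxy groups. Also open, from the compounds shown here alone, is how a hydroxyl group or an amine in the same place would behave on either core.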